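Adding a carboxy group to the ring nitrogen side chain of compound 3

A few compounds are considered here, and "the series" means these few. Any claim that something is new, unique, unknown or untested is made for them only; others in the source may bear on it.

Of the compounds shown here, three sharing one core have been measured in an assay for inhibition of Cholecystokinin receptor (Rattus norvegicus), read by CCK-8 assay; a higher number here means a weaker inhibitor, a lower number a stronger inhibitor. Compound 1 `CC(C)(C)OC(=O)CN1C(=O)C(NC(=O)c2ccccc2)CCc2ccccc21` gives 2100 nM. Among the compounds with values here, compound 2 `CN(C)c1ccc(C(=O)NC2CCc3ccccc3N(CC(=O)OC(C)(C)C)C2=O)cc1`, which carries a dimethylamino group, gives 50000 nM; that change, a 24-fold higher number from compound 1 to compound 2 (1.38 log units; beyond the scatter), was the only single-point step among the measured compounds. Compound 3 `CN1C(=O)C(NC(=O)c2ccc3ccccc3c2)CCc2ccccc21` gives 6800 nM, the second highest of the three numbers: it lies beyond the scatter from compound 1, with a lower number, and beyond the scatter from compound 2, with a higher number. Compound 3 and compound 1 differ in two places at once, so their values show only that the side chain on the ring nitrogen and the aromatic group together make a difference.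

Compound 4 `O=C(O)CN1C(=O)C(NC(=O)c2ccc3ccccc3c2)CCc2ccccc21` has not yet been measured. It differs from compound 3 by carboxy in place of hydrogen on a saturated chain carbon bound to an amide-type nitrogen in a ring. Within the data shown here, no measured step concerns this kind of change; the one step known, a 24-fold higher number from compound 1 to compound 2 (1.38 log units; beyond the scatter), touches an aromatic substituent and says nothing about the ring nitrogen side chain. The expectation therefore rests on compound 3 alone, with a wide range. Compound 4 is estimated to give 2500 nM, between 500 nM and 12000 nM, a step of a 2.7-fold lower number from compound 3 to compound 4 (0.43 log units; beyond the scatter) that is expected to lean toward a lower number but is uncertain.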

Compound 4, half-maximal inhibitory concentration: 2300 nM
Compound 4: middle estimate off by 1.1-fold (0.04 log units), on the high side; the measured number falls inside the stated range.
By their numbers in this assay, from the lowest: compounds 1 and 4 (each within the scatter of the next); then compound 3; then compound 2.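

In this assay, within the data shown here, the change of methyl to carboxymethyl gives the only single-point reading at this position: carboxy in place of hydrogen on a saturated chain carbon bound to an amide-type nitrogen in a ring gives a 3.0-fold lower number from compound 3 to compound 4 (0.47 log units; beyond the scatter) as a modest step. Compounds 1 and 3 differ in two places at once, so they could not separate the side chain from the aromatic group, whereas this pair shows that the side chain alone can shift the number beyond the scatter. The shift is toward a stronger inhibitor, so on this core the position accepts a carboxy group without loss, but nothing measured here bears on why the number moves.

The compounds shown leave open whether the carboxylic acid itself matters or whether any longer chain would do the same, which a plain ethyl group, a primary amide or an amine at this position could help to separate. They also leave open whether the same step would hold on the core of compound 1, with its different aromatic group.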